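This account rests on a few compounds, and the source may have more. Where it says the series, first, only, none or still open, it means among the compounds named here.

In a functional assay on BXPC-3 cells (Homo sapiens) for antiproliferative activity, read by sulforhodamine B assay, with a stated time of 72 h (a lower number here means a stronger inhibitor, a higher number a weaker inhibitor), compound 1 `CCCSc1ccc2c3c(cccc13)C1=NC(=O)C(C(=O)OCC)=C12` gives 5800 nM, the highest of the two numbers recorded so far. For the measured compounds named here, its nearest neighbour is compound 2 `C=CCOC(=O)C1=C2C(=NC1=O)c1cccc3cccc2c13`, which in this assay gives 4800 nM; the two values lie within the scatter of each other, so nothing separates them, and compound 2 differs from compound 1 in more than one place, so its value shows only that the two compounds behave alike. The next compound, compound 3 `C=CCSc1ccc2c3c(cccc13)C1=NC(=O)C(C(=O)OCC)=C12`, awaits measurement in this assay. It differs from compound 1 in one place: vinyl in place of ethyl on a saturated chain carbon bound to a sulfur. Going by the values given here, no step between two measured compounds isolates an exchange of this kind, so there is no measured guide to its size. With the exchange confined to the chain bound to the sulfur, and the shared core untouched, compound 3 is expected to stay close to compound 1, with a step of a 1.2-fold lower number from compound 1 to compound 3 (0.06 log units; within the scatter) that is expected to fall within the scatter in either direction. Compound 3 is therefore estimated at 5000 nM, with a range from 2000 nM to 14000 nM.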

Compound 3, half-maximal inhibitory concentration: 2500 nM
For compound 3 the middle estimate is 2.0-fold (0.30 log units) above the measured one; the measured number falls inside the stated range.
By their numbers in this assay, from the lowest: compounds 3, 2 and 1 (each within the scatter of the next, the first and the last beyond it).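

In this assay the exchange of ethyl for vinyl on a saturated chain carbon bound to a sulfur gives a 2.3-fold lower number from compound 1 to compound 3 (0.37 log units; beyond the scatter) and is the first single-place step that can be read in this set, so this chain is shown to be a place where the number can move. The step is modest, yet the exchange leaves the count of heavy atoms unchanged and adds only one double bond outside aromatic rings, which shows that even a small alteration here, read one bond further out as propylsulfanyl to allylsulfanyl, carries beyond the scatter. Nothing available explains the step, so it stands as an observation without a cause.

The compounds shown leave open whether the lower number belongs to the double bond or would also appear with other groups on the sulfur, such as a propargyl group, a benzyl group or a longer chain like butyl. They also leave open what a chain ending in an amine or a carboxylic acid would do at this place, and whether the same exchange would have a similar effect with the ethyl ester of the shared core replaced.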